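Swapping the Bromophenyl Ketone for a Nitrophenyl Ketone

This account rests on a few compounds, and the source may have more. Where it says the series, first, only, none or still open, it means among the compounds named here.

Of the compounds shown here, three that share one core have been measured. In a functional assay on MCF7 cells (Homo sapiens) for cytotoxicity, read by MTT assay, with a stated time of 48 h (a higher number here means a weaker inhibitor, a lower number a stronger inhibitor), compound 1 `COc1cc(-c2nnc3n2NC(c2ccco2)C(C(=O)c2cccc(Br)c2)S3)cc(OC)c1OC` gives 91800 nM. Compound 2 `COc1cc(-c2nnc3n2NC(c2ccco2)C(C(=O)c2ccc(C(F)(F)F)cc2)S3)cc(OC)c1OC` gives 33600 nM in this assay. For compound 3 `COc1cc(C(=O)C2Sc3nnc(-c4cc(OC)c(OC)c(OC)c4)n3NC2c2ccco2)cc(OC)c1OC` the measurement reached only a limit of the assay, > 100000 nM, so no number is known for it. Of the two numbers in hand, compound 1 holds the higher one: a 2.7-fold lower number from compound 1 to compound 2 (0.44 log units; beyond the scatter). The remaining comparisons are an at least 1.0-fold higher number from compound 1 to compound 3 (0.03 log units; that floor lies within the scatter) and an at least 2.9-fold higher number from compound 2 to compound 3 (0.47 log units; beyond the scatter).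

Compound 4 `COc1cc(-c2nnc3n2NC(c2ccco2)C(C(=O)c2ccc([N+](=O)[O-])cc2)S3)cc(OC)c1OC` has not yet been measured. It differs from compound 1 in a single place: 4-nitrophenyl in place of 3-bromophenyl on a carbonyl carbon. The measured steps that bear on this change are the two that also exchange the aryl group on the carbonyl carbon. Exchanging it for 4-(trifluoromethyl)phenyl lowered the number modestly, while exchanging it for 3,4,5-trimethoxyphenyl produced no change beyond the scatter and left only a limit. A modest step is therefore the most that the data support, and its direction is uncertain. Compound 4 is expected to give about 60000 nM in this assay, with a range from 25000 nM to 120000 nM. That estimate amounts to an expected step of a 1.5-fold lower number from compound 1 to compound 4 (0.18 log units; within the scatter).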

Compound 4, half-maximal inhibitory concentration: > 100000 nM
Compound 4 was reported as a limit; the forecaster's own chance of this, stated with the estimate: 25%; at least 1.6-fold (0.22 log units) between middle value and limit.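

Placing 4-nitrophenyl on the carbonyl carbon gives a limit of the assay rather than a number, and against the bromophenyl compound the result reads as an at least 1.0-fold higher number from compound 1 to compound 4 (0.03 log units; that floor lies within the scatter), so compound 4 cannot be separated from compound 1. For the compounds shown here, the more informative comparison is with the trifluoromethyl compound, where nitro in place of trifluoromethyl on an aromatic carbon gives an at least 2.9-fold higher number from compound 2 to compound 4 (0.47 log units; beyond the scatter), which shows that exchanging only this one group on the ring can shift the result in this assay beyond the scatter. The step between the nitrophenyl and trimethoxyphenyl compounds cannot be read, because each of them stands only at a limit: the limit of > 100000 nM in this assay, at which 2 of the 4 values shown sit.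

Going by these compounds, how far compound 4 actually lies past that limit remains unknown, so the size of its difference from compound 2 has only a floor. On these data alone, it also remains open whether an amine or a carboxylic acid on the same phenyl ring would give a number closer to that of compound 2, or would likewise end at the limit.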